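A few compounds are considered here, and "the series" means these few. Any claim that something is new, unique, unknown or untested is made for them only; others in the source may bear on it.

Measured so far:
Compound 1 `COc1ccc(-c2cc3c(OC)ccc(OC)c3nc2O)cc1`: 10000 nM
Compound 2 `CCOC(=O)Cn1c(=O)c(-c2ccc(OC)cc2)cc2c(OC)cc(OC)cc21`: 10000 nM

In a functional assay on U-87MG ATCC cells for cytotoxicity against U-87 MG (Homo sapiens), read by colorimetric assay and MTT assay (on this read-out higher numbers stand for weaker inhibition and lower numbers for stronger inhibition), compound 2 gives 10000 nM, and compound 1 gives 10000 nM, so the two values are the same at the digits available. The next compound, compound 3 `COC(=O)CCn1c(=O)c(-c2ccc(OC)cc2)cc2c(OC)cc(OC)cc21`, has the same atoms as compound 2, joined differently: (methoxycarbonyl)methyl in place of ethoxycarbonyl on a saturated chain carbon bound to an aromatic nitrogen. Put another way, (ethoxycarbonyl)methyl becomes 2-(methoxycarbonyl)ethyl. Going by the values given here, no two measured compounds differ in only one place, so the data hold no direct precedent for this change. The expectation in this assay therefore rests on compound 2 at 10000 nM, with no step beyond the usual scatter in either direction. The estimate is no change at the digits printed from compound 2 to compound 3 (within the scatter). For compound 3 the expected value is 10000 nM, within an estimated range of 4000 nM to 15000 nM.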

Compound 3, half-maximal inhibitory concentration: 10000 nM
Compound 3: middle estimate and measured number agree at the digits printed; low and high end bracket the measured number.
By their numbers in this assay, from the lowest: compounds 1, 2 and 3 (each within the scatter of the next).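

In this assay, going by these compounds alone, putting (methoxycarbonyl)methyl in place of ethoxycarbonyl on a saturated chain carbon bound to an aromatic nitrogen gives no change at the digits printed from compound 2 to compound 3 (within the scatter) and supplies the first comparison of two compounds that differ in one place. The same atoms, joined differently as 2-(methoxycarbonyl)ethyl rather than (ethoxycarbonyl)methyl, therefore leave this read-out unmoved for this pair of esters. No supporting measurement bears on why the number stays put.

Both compounds carry an ester here, so the pair cannot tell whether a carboxylic acid, an amine or a longer chain at this place would shift the value in this assay. Changes to the shared core also remain open.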